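Propoxy and Allyloxy Amides as Nicotinic Receptor Antagonists

The source may report more compounds than this note shows. Statements on the series, on what has been measured and on what is new or still open speak of the compounds shown alone.

Compound 1 `C=CCOc1ccc(C(=O)Nc2cccc(CC)n2)cc1`: 27400 nM
Compound 2 `CCCOc1ccc(C(=O)Nc2cccc(CC)n2)cc1`: 29200 nM
Compound 3 `CCCNc1cccc(NC(=O)c2ccc(OCCC)cc2)n1`: 12600 nM

These three amides were tested in an in vitro assay on HEK-tsA201 cells for antagonist activity at Neuronal acetylcholine receptor; alpha3/beta4 (Homo sapiens), read by fluorescence and calcium flux; on this read-out lower numbers stand for stronger inhibition and higher numbers for weaker inhibition. Compound 1 and compound 2 differ by vinyl in place of ethyl on a saturated chain carbon bound to an oxygen on an aromatic ring, and that exchange gave a 1.1-fold lower number from compound 2 to compound 1 (0.03 log units; within the scatter). The cores of compound 2 and compound 3 differ by propylamino in place of ethyl on an aromatic carbon, which gave a 2.3-fold lower number from compound 2 to compound 3 (0.37 log units; beyond the scatter), so compound 3 gives the lowest number of the three in this assay.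

Compound 4 `C=CCOc1ccc(C(=O)Nc2cccc(NCCC)n2)cc1` has not been measured. It differs from compound 3 by vinyl in place of ethyl on a saturated chain carbon bound to an oxygen on an aromatic ring, the same change seen from compound 2 to compound 1, at the same place. Because the earlier step was a 1.1-fold lower number from compound 2 to compound 1 (0.03 log units; within the scatter), compound 4 is expected to sit close to compound 3, with an expected step of a 1.1-fold lower number from compound 3 to compound 4 (0.04 log units; within the scatter). The estimate for compound 4 in this assay is 11500 nM.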

Compound 4, half-maximal inhibitory concentration: 11700 nM
For compound 4 the middle estimate is 1.0-fold (0.01 log units) below the measured one; the measured number falls inside the stated range.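

Changing propoxy to allyloxy on the propylamino core gave a 1.1-fold lower number from compound 3 to compound 4 (0.03 log units; within the scatter), which matches the step on the ethyl core: the same change on two cores in this assay, a 1.1-fold lower number (0.03 log units; within the scatter) from compound 2 to compound 1 and a 1.1-fold lower number (0.03 log units; within the scatter) from compound 3 to compound 4, 1.0-fold (0.00 log units) apart, within the scatter of two such steps

Putting propylamino in place of ethyl on the allyloxy core gave a 2.3-fold lower number from compound 1 to compound 4 (0.37 log units; beyond the scatter), which also repeats the earlier step: the same change on two cores in this assay, a 2.3-fold lower number (0.37 log units; beyond the scatter) from compound 2 to compound 3 and a 2.3-fold lower number (0.37 log units; beyond the scatter) from compound 1 to compound 4, 1.0-fold (0.00 log units) apart, within the scatter of two such steps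

Across these two cores, the step from propoxy to allyloxy stays within the scatter and the propylamino step stays modest, but the two comparisons use the same four compounds, so they form one check rather than two and show nothing about other cores.

Going by these compounds, it remains open how a longer chain in place of propylamino, or a dimethylamino group there, would read. A butoxy chain in place of propoxy is also untested among the compounds shown here.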